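This account rests on a few compounds, and the source may have more. Where it says the series, first, only, none or still open, it means among the compounds named here.

Measured so far:
Compound 1 `CC(C)N(Cc1cccc(OCCCCCC(=O)O)c1)C(=O)c1ccc(-c2cccc3ccccc23)cc1`. In an ADME assay on Raji cells (Homo sapiens) for cytotoxicity, read by CellTiter-Glo and resazurin assay, with a stated time of 72 h (on this read-out higher numbers stand for an effect only at larger amounts of compound and lower numbers for an effect already at smaller amounts), compound 1 gives > 26000 nM, which is a limit of the assay.
Compound 2 `COc1cccc(-c2ccc(C(=O)N(Cc3cccc(OCCCCCC(=O)O)c3)C(C)C)cc2)c1`. In this assay compound 2 gives > 20900 nM, again a limit.
Compound 3 `CCOC(=O)CCCCCOc1cccc(CN(C(=O)c2ccc(-c3cccc4ccccc34)cc2)C(C)C)c1`. In this assay compound 3 gives > 26000 nM, also a limit.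

Compound 3 therefore stands at the limit of > 26000 nM in this assay, at which 2 of the 3 values shown sit, the same limit as compound 1, while compound 2 sits at the limit of > 20900 nM in this assay, at which 1 of the 3 values shown sits. For the measured compounds named here, every value is a limit, so no compound can be placed above or below another, and the two steps that connect them, a step that the two limits leave unreadable from compound 1 to compound 2 and a step that the two limits leave unreadable from compound 1 to compound 3, have no readable size.

Compound 4 `CCOC(=O)CCCCCOc1cccc(CN(C(=O)c2ccc(-c3ccco3)cc2)C(C)C)c1` carries the ester of compound 3 and differs by furan-2-yl in place of naphthalen-1-yl on an aromatic carbon. Going by the values given here, the only step that touches the same aromatic carbon is the one from compound 1 to compound 2, where a 3-methoxyphenyl replaced the naphthalen-1-yl, and it was left unreadable by two limits. Among the compounds with values here, there is thus no measured step that sets a direction or a size for the change to compound 4.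

On the three limits shown, compound 4 is expected to remain without a readable effect in this assay; the expected step that the limit leaves unreadable from compound 3 to compound 4 is none beyond the scatter. Compound 4 is estimated at 30000 nM, in a range of 15000 nM to 60000 nM.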

Compound 4, half-maximal effective concentration: > 26000 nM
Compound 4 ended at the assay's limit (the forecaster's own chance of this, stated with the estimate: 85%); the middle value lies beyond the limit too.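

Compound 3 and compound 4 sit at the same limit of the assay: the limit of > 26000 nM in this assay, at which 3 of the 4 values shown sit.

The exchange of naphthalen-1-yl for furan-2-yl between compound 3 and compound 4 therefore has no readable size or direction. The compounds shown leave open at what concentration, if any, compound 1, compound 2, compound 3 or compound 4 would show an effect in this assay.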